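The source may hold more compounds than are shown below. What is called first, only, known or untested is meant among the compounds shown, and "the series" means these compounds.

In a toxicity assay on NIH3T3 cells (Mus musculus) for cytotoxicity, read by resazurin assay (a higher number here means that more compound is needed for the effect, a lower number that less compound is needed), compound 2 `COC(=O)c1ccc(NCc2cncn2Cc2ccccc2)cc1-c1ccccc1` gives > 1000 nM, which is a limit and not a number. Compound 1 `CN(C)c1ccc(NCc2cncn2Cc2ccc(-c3ccccc3)cc2)cc1-c1ccccc1` gives > 1000 nM, also a limit. Compound 3 `O=C(c1ccc(NCc2cncn2Cc2ccc(-c3ccccc3)cc2)cc1-c1ccccc1)N1CCCCC1` gives > 1000 nM, again a limit. The measured picture is therefore uniform, with the limit of > 1000 nM in this assay, at which 3 of the 3 values shown sit. Compound 4 `COC(=O)c1ccc(NCc2cncn2Cc2ccccc2Cl)cc1-c1ccccc1` differs from compound 2 by one change, chloro in place of hydrogen on an aromatic carbon, turning benzyl into 2-chlorobenzyl. For the measured compounds named here, the only measured step, a step that the two limits leave unreadable from compound 1 to compound 3, involves a different change, and its size cannot be read, so it offers no size to carry over. The estimated step is a step that the limit leaves unreadable from compound 2 to compound 4, which means none beyond the usual scatter is expected. Compound 4 is expected at 1500 nM, within an estimated range of 600 nM to 5000 nM.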

Compound 4, half-maximal effective concentration: 10000 nM
Beside the measured number, compound 4's estimate is 6.7-fold (0.82 log units) below it, outside the stated range (above it).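

The step from compound 2 to compound 4 cannot be read, because compound 2 has a limit and not a number: the limit of > 1000 nM in this assay, at which 3 of the 4 values shown sit. Left open is how much chloro in place of hydrogen changes the value in this assay.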